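Removing a Ring Chloro Group in a Cytotoxicity Series

The compounds below may be only part of what the source reports. "The series", "measured", "known", "first", "only" and "open" are said of these compounds alone.

Measured compounds:
compound 1, `O=c1nc2ccc(Br)cn2cc1Cc1ccc(Cl)cc1`: > 1000000 nM, a limit of the assay
compound 2, `O=c1nc2ccc(Cl)cn2cc1Cc1ccc(F)cc1`: 10400 nM
compound 3, `O=c1nc2ccc(Br)cn2cc1Cc1ccccc1`: > 1000000 nM, a limit of the assay

Three compounds were tested in a functional assay on MCF7 cells (Homo sapiens) for cytotoxicity, read by MTT assay, with a stated time of 24 h; on this read-out lower numbers stand for stronger inhibition and higher numbers for weaker inhibition. Compound 1 reaches only the limit > 1000000 nM. Compound 3 likewise gives only the limit > 1000000 nM. Within the data shown here, compound 2 gives 10400 nM, the single value that is a number; (the limit of > 1000000 nM in this assay, at which 2 of the 3 values shown sit). The step that the two limits leave unreadable from compound 1 to compound 3 corresponds to hydrogen in place of chloro on an aromatic carbon. The difference between the cores of compound 1 and compound 2 is not broken down here.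

Compound 4, `O=c1nc2ccccn2cc1Cc1ccc(F)cc1`, has not been measured. It differs from compound 2 by hydrogen in place of chloro on an aromatic carbon, the same kind of change as from compound 1 to compound 3 but at a different place: there the chloro sat on a six-membered aromatic ring of carbon only, para to a large group; here it sits on a six-membered aromatic ring with 1 nitrogen, part of a fused system, two atoms from the ring nitrogen. Because a step that the two limits leave unreadable from compound 1 to compound 3 is unreadable, the earlier pair gives no size to lean on. The step of a 1.9-fold higher number from compound 2 to compound 4 (0.28 log units; within the scatter) is therefore expected to be modest, resting only on compound 2 at 10400 nM. Compound 4 is estimated at 20000 nM, between 5000 nM and 100000 nM.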

Compound 4, half-maximal inhibitory concentration: 200000 nM
The estimate for compound 4 lay 10-fold (1.00 log units) below the measured number, and the stated range ends below it.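

In this assay, hydrogen in place of chloro on an aromatic carbon, two atoms from the ring nitrogen, gives a 19-fold higher number from compound 2 to compound 4 (1.28 log units; beyond the scatter), so at this place in the series the chloro cannot be removed without a large loss. The same kind of change on the six-membered aromatic ring of carbon only, in the pair compound 1 and compound 3, cannot be read, because both values are limits of the assay and not numbers: the limit of > 1000000 nM in this assay, at which 2 of the 4 values shown sit. Among these compounds, the one readable step therefore stands alone, and it neither shows nor rules out that removing a chloro has a similar effect at the other place or on the other core.

The compounds shown leave open whether a methyl, a methoxy or an amine at the place of the chloro would keep the value of compound 2, 10400 nM. They also leave open how a nitrile or a carboxylic acid at that place would compare with compound 4.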